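Trimming the chain on the core nitrogen: compound 3 to compound 4

The source may hold more compounds than are shown below. What is called first, only, known or untested is meant among the compounds shown, and "the series" means these compounds.

The three measured compounds and their values:
compound 1 `CCCCn1c(Cc2c(Br)c(OC)c(OC)c(OC)c2Br)nc2c(N)ncnc21` gives 30200 nM
compound 2 `C#CCCn1c(Cc2cc(OC)c(OC)c(OC)c2)nc2c(N)nc(F)nc21` gives 25100 nM
compound 3 `COc1cc(Cc2nc3c(N)ncnc3n2CC(C)C)cc(OC)c1OC` gives 97700 nM

All three were tested in a functional assay on MCF7 cells (Homo sapiens) for antiproliferative activity; on this read-out higher numbers stand for weaker inhibition and lower numbers for stronger inhibition. Among these numbers compound 3 stands highest, and its steps to compound 1 and to compound 2 are both beyond the usual scatter, so on these figures compound 3 is the weakest of the three. The other two compounds differ from it in more than one place, so no single change can be read from them.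

The next compound, compound 4 `COc1cc(Cc2nc3c(N)ncnc3n2C)cc(OC)c1OC`, is not yet measured. It differs from compound 3 in one place only: hydrogen in place of isopropyl on a saturated chain carbon bound to an aromatic nitrogen. For the measured compounds named here, no step between measured compounds shows what this kind of change does, so there is nothing to lean on besides the three numbers themselves. Compound 3 already sits at the weak end, and a step of modest size, perhaps toward a higher number, or none beyond the scatter, is expected from compound 3 to compound 4, as a 1.2-fold higher number from compound 3 to compound 4 (0.09 log units; within the scatter). For compound 4 the estimate is 120000 nM, within a range from 35000 nM to 400000 nM.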

Compound 4, half-maximal inhibitory concentration: 70800 nM
The estimate for compound 4 lay 1.7-fold (0.23 log units) above the measured number; measured number inside the range.
By their numbers in this assay, from the lowest: compounds 2 and 1 (each within the scatter of the next); then compounds 4 and 3 (each within the scatter of the next).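

Replacing isopropyl with hydrogen on a saturated chain carbon bound to an aromatic nitrogen, which is the same as cutting isobutyl to methyl, gives a 1.4-fold lower number from compound 3 to compound 4 (0.14 log units; within the scatter) in this assay. For the compounds shown here, this is the first comparison that isolates a single change, and it shows that removing these 3 carbons leaves the number within the usual scatter. So, between these two compounds, the size of the chain makes no readable difference on this read-out, and nothing available offers an explanation for that.

Going by these compounds, whether a different kind of group at this place, such as an amine or a carboxylic acid, would shift the number beyond the scatter remains open. Compound 1 and compound 2 differ from these two in more than one place, so the contribution of their chains cannot be read.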